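A Methyl-Bearing Indolyl Group Replaces a Plain One

The source may hold more compounds than are shown below. What is called first, only, known or untested is meant among the compounds shown, and "the series" means these compounds.

In a functional assay on K562 cells (Homo sapiens) for inhibition, read by trypan blue exclusion, with a stated time of 72 h (a higher number here means a weaker inhibitor, a lower number a stronger inhibitor), compound 1 (`Cn1c(=O)c(S(=O)(=O)c2ccc(F)cc2F)cc2cnc(Nc3ccc4[nH]c(C(=O)O)cc4c3)nc21`) gives 10000 nM and compound 2 (`Cn1c(=O)c(S(=O)(=O)c2ccc(F)cc2F)cc2cnc(Nc3ccc4cc[nH]c4c3)nc21`) gives 5000 nM so these two readings lie within the usual scatter of each other and cannot be told apart. Compound 3 (`Cc1cc2cc(Nc3ncc4cc(S(=O)(=O)c5ccc(F)cc5F)c(=O)n(C)c4n3)ccc2[nH]1`) keeps the shared core and differs from compound 2 on a nitrogen on an aromatic ring, with 2-methyl-1H-indol-5-yl in place of 1H-indol-6-yl (2-methyl-1H-indol-5-yl in place of 1H-indol-6-yl on a nitrogen on an aromatic ring). Among the measured compounds shown here, only one measured step bears on this change: a 2.0-fold lower number from compound 1 to compound 2 (0.30 log units; within the scatter) which put 1H-indol-6-yl in place of 2-carboxy-1H-indol-5-yl and stayed within the scatter. A single step is thin evidence, and no shift beyond the scatter is expected in this assay in either direction. The expected step of a 1.2-fold higher number from compound 2 to compound 3 (0.08 log units; within the scatter) is estimated to stay within the scatter. Compound 3 is expected at 6000 nM with an estimated range from 2000 nM to 15000 nM as its likely span.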

Compound 3, half-maximal inhibitory concentration: 750 nM
Compound 3: middle estimate off by 8.0-fold (0.90 log units), on the high side; measured number below the stated range.
By their numbers in this assay, from the lowest: compound 3; then compounds 2 and 1 (each within the scatter of the next).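

In this assay, the group on this nitrogen now proves able to move the number: the earlier pair stayed within the scatter, but 2-methyl-1H-indol-5-yl in place of 1H-indol-6-yl gives a 6.7-fold lower number from compound 2 to compound 3 (0.82 log units; beyond the scatter). Among the compounds shown here, the contrast is larger still when methyl stands in place of carboxy on an aromatic carbon, with a 13-fold lower number from compound 1 to compound 3 (1.12 log units; beyond the scatter), and that comparison changes only this one group. The data shown offer no measurement that explains either step.

The step from compound 2 to compound 3 changes both the methyl and the point where the indole is attached, so the two contributions cannot be separated here; plain 1H-indol-5-yl would be the group that divides them. As far as these compounds go, how an ethyl group or an amine would read in place of the methyl also remains open.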